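Methoxyphenyl for cyanophenyl on the piperidine benzyl arm

The source may hold more compounds than are shown below. What is called first, only, known or untested is meant among the compounds shown, and "the series" means these compounds.

Measured so far, in a functional assay on the whole organism for antagonist activity, with Mus musculus as the target; a higher number here means that more compound is needed for the effect, a lower number that less compound is needed:
compound 1 `COc1cc(N)c(Cl)cc1NC(=O)C1CCN(CC2CC2)CC1` gives > 10 mg/kg
compound 2 `COc1cc(N)c(Cl)cc1NC(=O)C1CCN(Cc2cccc(C)c2)CC1` gives 2.4 mg/kg
compound 3 `COc1cc(N)c(Cl)cc1NC(=O)C1CCN(Cc2cccc(C#N)c2)CC1` gives > 4 mg/kg

Compound 1 and compound 3 are both known only as limits of this assay, not as numbers. Among the compounds with values here, compound 2 is the only compound of the three with a full value. Within the data shown here, the step of an at least 4.1-fold lower number from compound 1 to compound 2 (0.61 log units; beyond the scatter) is the one readable step beyond the scatter in the set. The step of an at least 1.6-fold higher number from compound 2 to compound 3 (0.22 log units; that floor lies within the scatter) has a floor that lies within the scatter, so compound 2 and compound 3 cannot be ordered with confidence. The step that the two limits leave unreadable from compound 1 to compound 3 is unreadable, as both ends are limits, the limit of > 10 mg/kg in this assay, at which 1 of the 3 values shown sits, and (the limit of > 4 mg/kg in this assay, at which 1 of the 3 values shown sits).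

Compound 4 `COc1ccc(CN2CCC(C(=O)Nc3cc(Cl)c(N)cc3OC)CC2)cc1` differs from compound 3 by 4-methoxyphenyl in place of 3-cyanophenyl on a saturated chain carbon bound to an amine nitrogen in a ring. Of the measured steps, only an at least 4.1-fold lower number from compound 1 to compound 2 (0.61 log units; beyond the scatter) speaks to an aryl group on this carbon, and it favours an aryl over cyclopropyl; the two aryl compounds 2 and 3 differ only within the scatter floor. Among the measured compounds shown here, the swap of a cyano for a methoxy on the aryl has no measured counterpart here, so no direction beyond the scatter is expected.

Compound 4 is therefore estimated to sit near compound 2, at 4 mg/kg with a range of 1.5 mg/kg to 15 mg/kg. This estimate implies a step of a number no higher from compound 3 to compound 4 (the limit leaves the size open) from the limit of compound 3, with a fair chance that this assay again reports only a limit.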

Compound 4, dose for half-maximal effect: 0.9 mg/kg
Compound 4: middle estimate off by 4.4-fold (0.65 log units), on the high side; measured number outside the range, below it.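

In this assay, within the data shown here, the choice of aryl group on this saturated chain carbon now makes a readable difference: a 2.7-fold lower number from compound 2 to compound 4 (0.43 log units; beyond the scatter), the first step between two aryl groups here that is printed as beyond the scatter. The same group also compares well with 3-cyanophenyl, an at least 4.4-fold lower number from compound 3 to compound 4 (0.64 log units; beyond the scatter), and with cyclopropyl, an at least 11-fold lower number from compound 1 to compound 4 (1.04 log units; beyond the scatter), although these two steps each start from a limit and give only a floor. Compound 4 therefore needs the least compound of the four, which shows that the outcome at this position depends on the aryl substituent and its place on the ring, not only on an aryl group being present.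

Each step to 4-methoxyphenyl changes both the substituent and its place on the ring, so the compounds shown cannot separate these two changes, and a 3-methoxyphenyl or 4-methylphenyl arm would be needed to tell them apart. None of the facts at hand bears on the reason for these steps.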